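Leaving the 5-isopropyl-1H-imidazol-4-yl group in this series

A few compounds are considered here, and "the series" means these few. Any claim that something is new, unique, unknown or untested is made for them only; others in the source may bear on it.

In a functional assay on NCI-H460 cells (Homo sapiens) for cytotoxicity, read by MTT assay, with a stated time of 72 h (a higher number here means a weaker inhibitor, a lower number a stronger inhibitor), compound 1 `CC(C)c1[nH]cnc1/C=c1\[nH]c(=O)/c(=C/c2cccc(Oc3ccc(F)cc3)c2)[nH]c1=O` gives 8.8 nM and compound 2 `CC(C)c1[nH]cnc1/C=c1\[nH]c(=O)/c(=C/c2cccc(C(=O)c3ccc(F)cc3)c2)[nH]c1=O` gives 3.2 nM, the lower of the two numbers, with a 2.8-fold lower number from compound 1 to compound 2 (0.44 log units; beyond the scatter). Compound 3 `O=c1[nH]/c(=C\C2CCCCC2)c(=O)[nH]/c1=C\c1cccc(Oc2ccc(F)cc2)c1` reads > 1000 nM in this assay, which is a limit of the assay. Compound 4 `Cc1ccc(/C=c2\[nH]c(=O)/c(=C/c3cccc(C(=O)c4ccc(F)cc4)c3)[nH]c2=O)o1` differs from compound 2 as follows: 5-methylfuran-2-yl in place of 5-isopropyl-1H-imidazol-4-yl on a double-bonded chain carbon bound to an aromatic carbon. The exchange lies on a double-bonded chain carbon bound to an aromatic carbon. Only compound 3 bears on this place, through the large at least 110-fold higher number from compound 1 to compound 3 (2.05 log units; beyond the scatter). A five-membered aromatic ring remains in compound 4, so a clear but smaller rise is expected in this assay. The expected step is a 19-fold higher number from compound 2 to compound 4 (1.27 log units; beyond the scatter). For compound 4 the estimate is 60 nM, with an expected range of 8 nM to 450 nM.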

Compound 4, half-maximal inhibitory concentration: 5.3 nM
Estimate against measurement, compound 4: 11-fold (1.05 log units) above; the whole stated range lies above it.
By their numbers in this assay, from the lowest: compounds 2, 4 and 1 (each within the scatter of the next, the first and the last beyond it). At a limit, above all of these: compound 3.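

In this assay, 5-methylfuran-2-yl in place of 5-isopropyl-1H-imidazol-4-yl gives a 1.7-fold higher number from compound 2 to compound 4 (0.22 log units; within the scatter), so this place tolerates at least one exchange of the group. The large change with cyclohexyl, an at least 110-fold higher number from compound 1 to compound 3 (2.05 log units; beyond the scatter), therefore does not extend to every replacement on this double-bonded chain carbon, although that step belongs to the 4-fluorophenoxy pair and not the (4-fluorophenyl)carbonyl pair. The cyclohexyl comparison rests on a limit: the limit of > 1000 nM in this assay, at which 1 of the 4 values shown sits.

From the compounds shown here alone, whether cyclohexyl gives the same loss alongside (4-fluorophenyl)carbonyl remains open. Going by these compounds, how a phenyl ring or a carboxylic acid would read at this place is also open.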